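The source may hold more compounds than are shown below. What is called first, only, known or untested is meant among the compounds shown, and "the series" means these compounds.

Compound 3 `CC(C)C[C@H](N)CN(C(=O)[C@@H]1C[C@H]1c1ccccc1)c1ccc(C2=CCCCCC2)cc1` gives 2100 nM in a functional assay for agonist activity at G protein-coupled receptor 88 (Homo sapiens), read by HTRF and cAMP accumulation (on this read-out higher numbers stand for an effect only at larger amounts of compound and lower numbers for an effect already at smaller amounts), the highest number among the three measured compounds. Compound 1 `CC(C)[C@H](N)CN(C(=O)[C@@H]1C[C@H]1c1ccccc1)c1ccc(-c2ccccc2)cc1` gives 1.1 nM and compound 2 `O=C([C@@H]1C[C@H]1c1ccccc1)N(CCNCC1CCCCC1)c1ccc(-c2ccccc2)cc1` gives 6.6 nM in this assay; both carry a phenyl on the aromatic carbon where compound 3 carries cyclohept-1-en-1-yl, and both stand far below compound 3. Within the data shown here, the only single-place step measured, a 6.0-fold higher number from compound 1 to compound 2 (0.78 log units; beyond the scatter), concerns the saturated chain carbon bound to the amide-type nitrogen rather than the aromatic carbon, so it does not bear directly on the change at hand. Compound 4 `CC(C)C[C@H](N)CN(C(=O)[C@@H]1C[C@H]1c1ccccc1)c1ccc(-c2ccc(C#N)cc2)cc1` differs from compound 3 in one place: 4-cyanophenyl in place of cyclohept-1-en-1-yl on an aromatic carbon. Among the measured compounds shown here, no measured step covers this replacement; what the values of compound 1 and compound 2 show is that an aromatic ring at this position goes with numbers far lower than that of compound 3. On that ground a large fall in the number is expected, a 180-fold lower number from compound 3 to compound 4 (2.24 log units; beyond the scatter). Compound 4 is therefore estimated at 12 nM, within a range of 2 nM to 80 nM.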

Compound 4, half-maximal effective concentration: 670 nM
Estimate against measurement, compound 4: 56-fold (1.75 log units) below; the measured number lies above the stated range.
By their numbers in this assay, from the lowest: compound 1; then compound 2; then compound 4; then compound 3.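

In this assay, putting 4-cyanophenyl in place of cyclohept-1-en-1-yl on this aromatic carbon brings a 3.1-fold lower number from compound 3 to compound 4 (0.50 log units; beyond the scatter), a modest step though a real one. With the side chain of compound 3 held fixed, a six-membered aromatic ring at this position therefore does not by itself bring the numbers down steeply, so the aromatic ring alone cannot be read as the source of the low values seen earlier. Nothing available here gives a reason for the size of this step.

The step also joins two changes, the ring and its nitrile, and these cannot be told apart. As far as these compounds go, how a plain phenyl, or a methoxy group or carboxylic acid in place of the nitrile, would stand on this same side chain remains open.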